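A few compounds are considered here, and "the series" means these few. Any claim that something is new, unique, unknown or untested is made for them only; others in the source may bear on it.

In an ADME assay on BJ cells (Homo sapiens) for cytotoxicity, with a stated time of 72 h (on this read-out lower numbers stand for an effect already at smaller amounts and higher numbers for an effect only at larger amounts of compound), compound 1 (`Cc1cc(NC(=O)Nc2cccc(F)c2)c2ccccc2n1`) gives > 25000 nM as a limit and not a number. Its standing therefore rests on the limit of > 25000 nM in this assay, at which 1 of the 3 values shown sits, and on nothing finer. Compound 2 (`COc1ccc(NC(=O)Nc2cc(C)nc3ccccc23)cc1F`) gives 26000 nM and compound 3 (`COc1cccc(NC(=O)Nc2cc(C)nc3ccccc23)c1`) gives 27000 nM in this assay as well. Compound 4 (`Cc1cc(NC(=O)Nc2cc(F)ccc2F)c2ccccc2n1`) departs from compound 1 through fluoro in place of hydrogen on an aromatic carbon and through nothing else. Within the data shown here, two measured steps bear on this only loosely, and both bring in methoxy and not fluoro: there is a step that the limit leaves unreadable from compound 1 to compound 2 and there is a step that the limit leaves unreadable from compound 1 to compound 3 with no size to carry over. No change beyond the scatter is expected, and the expected result is a step that the limit leaves unreadable from compound 1 to compound 4 with no direction claimed. Compound 4 is estimated at 27000 nM with a range of 15000 nM to 45000 nM in this assay and may again return only a limit.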

Compound 4, half-maximal effective concentration: 7000 nM
Estimate against measurement, compound 4: 3.9-fold (0.59 log units) above; measured number below the stated range.
By their numbers in this assay, from the lowest: compound 4; then compounds 2 and 3 (each within the scatter of the next).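

Among these compounds, there is an at least 3.5-fold lower number from compound 1 to compound 4 (0.55 log units; beyond the scatter) in this assay with fluoro in place of hydrogen on an aromatic carbon, ortho to a large group and para to a fluoro group, and this is the only step from compound 1 that can be read, the earlier ones being unreadable. Among the compounds shown here, this single change at this place thus moves the number beyond the scatter, which the earlier compounds could not show. As far as these compounds go, compound 1 stands at a limit and not a number, so the full size of the step stays unknown because of this: the limit of > 25000 nM in this assay, at which 1 of the 4 values shown sits. From the compounds shown here alone, whether chloro or an amine at this same place would lower the number as well stays open.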